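The compounds below may be only part of what the source reports. "The series", "measured", "known", "first", "only" and "open" are said of these compounds alone.

Compound 1 `COc1ccc(C(=O)/C=C/c2cc(OC)c(OC)c(OC)c2)c2c1C=CC(C)(C)O2`: > 10000 nM in a functional assay on K562 cells (Homo sapiens) for antiproliferative activity, read by MTT assay, with a stated time of 24 h (on this read-out higher numbers stand for weaker inhibition and lower numbers for stronger inhibition), a limit of the assay.
Compound 2 `COc1ccc(C(=O)/C=C/c2cccc(F)c2)c2c1C=CC(C)(C)O2`: > 10000 nM in this assay, again a limit.
Compound 3 `COc1ccc(C(=O)/C=C/c2ccc(N(c3ccccc3)c3ccccc3)cc2)c2c1C=CC(C)(C)O2`: > 10000 nM in this assay, also a limit.

The three measured compounds share one core and differ only in the aryl group on the enone, and every value sits at the limit of > 10000 nM in this assay, at which 3 of the 3 values shown sit. Compound 2 therefore stands at the limit of this assay, and no order can be read among the three. Compound 4 `COc1ccc(C(=O)/C=C/c2cccc([N+](=O)[O-])c2)c2c1C=CC(C)(C)O2` differs from compound 2 by nitro in place of fluoro on an aromatic carbon. Among the measured compounds shown here, no step between measured compounds exists here, so the change is expected to bring no shift beyond the scatter in this assay, and a limit is again the most likely report. Compound 4 is estimated at 15000 nM, between 5000 nM and 50000 nM, which means a step that the limit leaves unreadable from compound 2 to compound 4.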

Compound 4, half-maximal inhibitory concentration: 5870 nM
Estimate against measurement, compound 4: 2.6-fold (0.41 log units) above; the range from low to high includes it.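

Among the compounds shown here, compound 4, with its 3-nitrophenyl group, gives the first reading in this assay that is a number and not a limit. The change from 3-fluorophenyl brings an at least 1.7-fold lower number from compound 2 to compound 4 (0.23 log units; that floor lies within the scatter) and so fixes only a floor, which does not set the two compounds apart. As far as these compounds go, the size of the step stays unknown, since compound 2 gives no number: the limit of > 10000 nM in this assay, at which 3 of the 4 values shown sit.

The compounds shown leave open whether an amine or a carboxylic acid on this aromatic carbon would give a lower number than the nitro group. They also leave open how a nitro group would read on another carbon of that ring.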